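A few compounds are considered here, and "the series" means these few. Any claim that something is new, unique, unknown or untested is made for them only; others in the source may bear on it.

Series notes. Compound 1 `C=CC(=C)CC[C@@H]1[C@@]2(C)CCC[C@](C)(COC(=O)/C=C/c3ccc(O)cc3)[C@@H]2CC[C@@]1(C)O` carries an ester on a bicyclic core; in a functional assay on MCF7 cells (Homo sapiens) for cytotoxicity, read by MTT assay, with a stated time of 48 h (on this read-out higher numbers stand for weaker inhibition and lower numbers for stronger inhibition), compound 1 gives 16600 nM. Compound 2 `C=C1CC[C@@H]2[C@](C)(CCC[C@]2(C)C(=O)O)[C@H]1CC/C(C)=C/CO` is a bicyclic acid with an allylic alcohol in the side chain. In this assay compound 2 reaches only the limit, > 40000 nM, so no number stands for it. Compound 3 `C=C1CC[C@@H]2[C@](C)(CCC[C@@]2(C)C(=O)O)[C@H]1CC/C(C)=C/COC(C)=O` is the acetate of that alcohol chain. In this assay compound 3 likewise gives only the limit, > 40000 nM. Compound 2 thus stands on (the limit of > 40000 nM in this assay, at which 2 of the 3 values shown sit), and only compound 1 has a numerical value in this assay. Within the data shown here, no step between measured compounds that differ in one place is available, so the series gives no measured direction for a single change.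

Compound 4 `C=C1CC[C@@H]2[C@](C)(CCC[C@]2(C)C(=O)O)[C@H]1C/C=C(\C)C=O` is the next target. It differs from compound 2 as follows: 2-formylprop-1-en-1-yl in place of 4-hydroxy-2-methylbut-2-en-1-yl on a saturated chain carbon bound to a saturated ring carbon. The 4-hydroxy-2-methylbut-2-en-1-yl group leaves and 2-formylprop-1-en-1-yl enters, on a saturated chain carbon bound to a saturated ring carbon. Whether this move shifts cytotoxicity cannot be read from the measured pairs, since compound 2 and compound 3 both sit at the limit. A move toward stronger inhibition, beyond the scatter, is expected: an at least 2.0-fold lower number from compound 2 to compound 4 (0.30 log units; that floor lies within the scatter). Compound 4 is estimated at about 20000 nM, between 6000 nM and 60000 nM, with a real chance that this assay again reports only a limit.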

Compound 4, half-maximal inhibitory concentration: > 40000 nM
Compound 4 gave a limit, no number (the forecaster's own chance of this, stated with the estimate: 40%); middle value at least 2.0-fold (0.30 log units) away from the limit.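

In this assay compound 4 gives > 40000 nM, which is a limit. Compound 2 and compound 4 both stand at a limit, so no step between them can be read: the limit of > 40000 nM in this assay, at which 3 of the 4 values shown sit.

The compounds shown leave open whether 2-formylprop-1-en-1-yl in place of 4-hydroxy-2-methylbut-2-en-1-yl shifts cytotoxicity at all.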